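Thiophen-2-yl to 4-hydroxyphenyl on compound 3

This account rests on a few compounds, and the source may have more. Where it says the series, first, only, none or still open, it means among the compounds named here.

Values in a functional assay on HL-60 cells (Homo sapiens) for cytotoxicity, read by ELISA, with a stated time of 2 days; a lower number here means a stronger inhibitor, a higher number a weaker inhibitor:
compound 1 `Oc1cccc(-c2cc(-c3ccccc3)cc(-c3cccs3)n2)c1`: 14100 nM
compound 2 `Oc1cccc(-c2cc(-c3ccccc3)cc(-c3cccc(O)c3)n2)c1`: 16400 nM
compound 3 `Oc1ccc(-c2cc(-c3ccccc3)cc(-c3cccs3)n2)cc1`: 1700 nM

Compound 3 has the lowest number of the three at 1700 nM, and its gaps to both others lie beyond the scatter. The next compound to consider is compound 4 `Oc1ccc(-c2cc(-c3ccccc3)cc(-c3ccc(O)cc3)n2)cc1`, in which 4-hydroxyphenyl takes the place of the thiophen-2-yl of compound 3, on an aromatic carbon next to the ring nitrogen: 4-hydroxyphenyl in place of thiophen-2-yl on an aromatic carbon.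

Among the compounds with values here, two measured steps bear on this change. The nearer one puts 3-hydroxyphenyl in place of thiophen-2-yl: a 1.2-fold higher number from compound 1 to compound 2 (0.07 log units; within the scatter). It exchanges the same leaving group for a hydroxyphenyl and shows no shift beyond the scatter. The other puts 4-hydroxyphenyl in place of 3-hydroxyphenyl: an 8.3-fold lower number from compound 1 to compound 3 (0.92 log units; beyond the scatter). Within the data shown here, that step lowered the number, but it concerns a different exchange, and no measured compound carries 4-hydroxyphenyl twice. The first step is therefore given more weight, with a wide margin on both sides.

The estimated change is a 1.4-fold higher number from compound 3 to compound 4 (0.15 log units; within the scatter), so no step beyond the scatter is expected in this assay. The expected value for compound 4 is 2400 nM, with an estimated range from 800 nM to 7000 nM.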

Compound 4, half-maximal inhibitory concentration: 5700 nM
For compound 4 the middle estimate is 2.4-fold (0.38 log units) below the measured one, and the stated range covers the measured number.
By their numbers in this assay, from the lowest: compound 3; then compound 4; then compounds 1 and 2 (each within the scatter of the next).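

In this assay the carbon next to the ring nitrogen now shows a response to losing thiophen-2-yl: with a 4-hydroxyphenyl group already on the core, 4-hydroxyphenyl in place of thiophen-2-yl gives a 3.4-fold higher number from compound 3 to compound 4 (0.53 log units; beyond the scatter). The earlier exchange at this position, with 3-hydroxyphenyl entering and a 3-hydroxyphenyl group already on the core, gave a 1.2-fold higher number from compound 1 to compound 2 (0.07 log units; within the scatter), so exchanging thiophen-2-yl for a hydroxyphenyl is not neutral in every setting within this small set. Nothing at hand accounts for the difference between these two steps.

Open, going by these compounds, is how a plain phenyl, a 4-methoxyphenyl or a 4-aminophenyl at this position would stand against thiophen-2-yl and 4-hydroxyphenyl, which would separate the role of the hydroxyl from that of the ring. Also open, on these data alone, is whether the step keeps its size when the 4-hydroxyphenyl group already on the core gives way to a ring carrying a carboxylic acid or an amine.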